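The source may report more compounds than this note shows. Statements on the series, on what has been measured and on what is new or still open speak of the compounds shown alone.

In an ADME assay on liver for metabolic stability, with Liver microsome (Homo sapiens) as the target, read by LC-MS, using microsomes (on this read-out higher numbers stand for fast clearance and lower numbers for slow clearance), compound 3 `O=C(NCc1cc(Cl)ccc1-n1cnnn1)[C@@H]1CC=NN1C(=O)[C@H](O)Cc1ccccc1` gives < 12 mL.min-1.g-1, which is a limit of the assay and not a number. Compound 1 `O=C(NCc1cc(Cl)ccc1-n1cnnn1)[C@@H]1CC=NN1C(=O)[C@H](O)c1ccccc1` gives < 12 mL.min-1.g-1, also a limit. Compound 2 `CC(C)(C)C[C@@H](O)C(=O)N1N=CC[C@H]1C(=O)NCc1cc(Cl)ccc1-n1cnnn1` gives a true number, 22 mL.min-1.g-1. Compound 3 therefore sits at the limit of < 12 mL.min-1.g-1 in this assay, at which 2 of the 3 values shown sit.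

Compound 4 `CCCC[C@@H](O)C(=O)N1N=CC[C@H]1C(=O)NCc1cc(Cl)ccc1-n1cnnn1` changes the end of the side chain: propyl in place of phenyl on a saturated chain carbon, two bonds along the chain from a carbonyl carbon and an oxygen on a saturated carbon. Cut one bond further out, this is benzyl to butyl.

Among the measured compounds shown here, two measured steps bear on this change. One is an at least 1.8-fold lower number from compound 2 to compound 3 (0.26 log units; that floor lies within the scatter), with phenyl in place of tert-butyl at the same place. The other is an at least 1.8-fold higher number from compound 1 to compound 2 (0.26 log units; that floor lies within the scatter), with neopentyl in place of phenyl. Both are small, and a step that the two limits leave unreadable from compound 1 to compound 3 adds nothing. Butyl carries no ring, and among the compounds measured, only compound 2 has a ringless chain, at 22 mL.min-1.g-1. The expected change in this assay is therefore a modest rise, an at least 1.5-fold higher number from compound 3 to compound 4 (0.17 log units; that floor lies within the scatter), which may not clear the scatter. For compound 4 the estimated value is 18 mL.min-1.g-1, with an expected range of 10 mL.min-1.g-1 to 35 mL.min-1.g-1.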

Compound 4, intrinsic clearance in microsomes: < 12 mL.min-1.g-1
Compound 4: a limit, no number (the forecaster's own chance of this, stated with the estimate: 30%); at least 1.5-fold (0.17 log units) between middle value and limit.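

In this assay compound 4 gives only a limit and not a number, the same limit that holds for the compounds with a ring in the side chain: the limit of < 12 mL.min-1.g-1 in this assay, at which 3 of the 4 values shown sit. A ringless chain at this place therefore does not by itself give a readable clearance, as compound 2 alone could have suggested, and the change of propyl for tert-butyl gives an at least 1.8-fold lower number from compound 2 to compound 4 (0.26 log units; that floor lies within the scatter). The steps that link compound 4 to compound 1 and to compound 3 have limits at both ends and cannot be read.

Among the compounds shown here, compound 2 remains the only compound with a true number, so no order can be given among compound 1, compound 3 and compound 4. From the compounds shown here alone, whether a longer chain, or an amine at the end of the chain, would give a number in this read-out stays open.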